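Furan-2-yl for Phenyl on an Oxazole Ketone

The source may hold more compounds than are shown below. What is called first, only, known or untested is meant among the compounds shown, and "the series" means these compounds.

Compound 1, `CCCCCCCC/C=C\CCCCCCC(=O)c1ncc(-c2ccccc2)o1`: 320 nM
Compound 2, `CCCCCCCC/C=C\CCCCCCC(=O)c1nc2ccccc2o1`: 370 nM
Compound 3, `CCCCCCCC/C=C\CCCCCCC(=O)c1nc2cnccc2o1`: 7.2 nM

Three compounds sharing a long unsaturated chain ending in a carbonyl on a five-membered aromatic ring have been measured in an assay on isolated protein for inhibition of Fatty-acid amide hydrolase 1 (Homo sapiens); on this read-out lower numbers stand for stronger inhibition and higher numbers for weaker inhibition. Compound 1 gives 320 nM, the second highest of the three numbers. Compound 2 gives 370 nM, which lies within the scatter of compound 1. Compound 3 gives 7.2 nM, a number far below that of compound 1 and beyond the scatter.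

Among the measured compounds shown here, the one step that can be computed, a 51-fold lower number from compound 2 to compound 3 (1.71 log units; beyond the scatter), changes the fused ring part of the core. The step from compound 1 to compound 4, `CCCCCCCC/C=C\CCCCCCC(=O)c1ncc(-c2ccco2)o1`, is of a different kind: furan-2-yl in place of phenyl on an aromatic carbon. For the measured compounds named here, no measured pair in this set changes that position, so nothing bears directly on it, and no step beyond the scatter is expected in this assay; the expected step is no change at the digits printed from compound 1 to compound 4 (within the scatter).

Compound 4 is therefore estimated at 320 nM in this assay, with a range from 100 nM to 1000 nM.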

Compound 4, inhibition constant: 54 nM
The estimate for compound 4 lay 5.9-fold (0.77 log units) above the measured number, outside the stated range (below it).
By their numbers in this assay, from the lowest: compound 3; then compound 4; then compounds 1 and 2 (each within the scatter of the next).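

In this assay, the aromatic carbon next to the ring oxygen, two ring bonds from the ring nitrogen, proves sensitive to the group it carries: furan-2-yl in place of phenyl gives a 5.9-fold lower number from compound 1 to compound 4 (0.77 log units; beyond the scatter). Among the compounds shown here, the only earlier step, a 51-fold lower number from compound 2 to compound 3 (1.71 log units; beyond the scatter), changed the fused ring part of the core and said nothing about this position, so this is the first sign that a change at this carbon can move the number beyond the scatter. The change replaces a six-membered aromatic ring of carbon only with a five-membered aromatic ring with 1 hetero atom and brings in 1 hydrogen-bond acceptor, but which of these differences matters cannot be told from this single pair, and nothing available here accounts for the step.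

As far as these compounds go, whether other groups on this aromatic carbon, such as thiophen-2-yl, pyridin-2-yl, an amine or a carboxylic acid, would lower the number further remains open. Also open, from the compounds shown here alone, is whether the step from phenyl to furan-2-yl would hold with a different chain on the carbonyl, such as a saturated one.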